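This account rests on a few compounds, and the source may have more. Where it says the series, first, only, none or still open, it means among the compounds named here.

Measured compounds:
compound 1 `COc1ccc(-c2c(C(=O)c3cc(OC)c(OC)c(OC)c3)sc3ccccc23)cc1` gives 1600 nM in a functional assay on Jurkat cells (Homo sapiens) for antiproliferative activity, read by MTT assay, with a stated time of 72 h; on this read-out higher numbers stand for weaker inhibition and lower numbers for stronger inhibition;
compound 2 `COc1cc(C(=O)c2sc3ccccc3c2-c2ccc(SC)cc2)cc(OC)c1OC` gives 1900 nM;
compound 3 `COc1ccc(-c2c(C(=O)c3cc(OC)c(OC)c(OC)c3)sc3ccccc23)c(OC)c1` gives 4000 nM.

On these numbers compound 2 sits between the other two: a 1.2-fold higher number from compound 1 to compound 2 (0.07 log units; within the scatter), while a 2.1-fold higher number from compound 2 to compound 3 (0.32 log units; beyond the scatter). Compound 4 `CCOc1ccc(Nc2c(C(=O)c3cc(OC)c(OC)c(OC)c3)sc3ccccc23)cc1` changes compound 2 in one place: (4-ethoxyphenyl)amino in place of 4-(methylsulfanyl)phenyl on an aromatic carbon. For the measured compounds named here, no measured step swaps an aryl group for an arylamino group at this carbon; the nearest comparisons are a 1.2-fold higher number from compound 1 to compound 2 (0.07 log units; within the scatter) and a 2.5-fold higher number from compound 1 to compound 3 (0.40 log units; beyond the scatter), both of which alter only substituents on the pendant ring. The step to compound 4 is larger than either, so the expectation is uncertain. In this assay compound 4 is estimated at 2500 nM, between 500 nM and 12000 nM, which would mean an expected step of a 1.3-fold higher number from compound 2 to compound 4 (0.12 log units; within the scatter).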

Compound 4, half-maximal inhibitory concentration: 300 nM
The estimate for compound 4 lay 8.3-fold (0.92 log units) above the measured number; the measured number lies below the stated range.
By their numbers in this assay, from the lowest: compound 4; then compounds 1 and 2 (each within the scatter of the next); then compound 3.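

In this assay the (4-ethoxyphenyl)amino group on this aromatic carbon gives a 6.3-fold lower number from compound 2 to compound 4 (0.80 log units; beyond the scatter) and a 5.3-fold lower number from compound 1 to compound 4 (0.73 log units; beyond the scatter) and a 13-fold lower number from compound 3 to compound 4 (1.12 log units; beyond the scatter). Each of these drops is larger than any step among the aryl groups compared earlier, so this position can tolerate more than a directly attached substituted phenyl ring and can give a lower number with an amino-linked one. Nothing given here explains this drop. Because the whole group changes at once, the shown compounds leave open how much comes from the amino link and how much from the ethoxy group. A plain phenylamino or a (4-methoxyphenyl)amino group at this carbon would separate the two.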